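A few compounds are considered here, and "the series" means these few. Any claim that something is new, unique, unknown or untested is made for them only; others in the source may bear on it.

Measured compounds:
compound 1 `CC(=O)c1cc(-c2ccccc2)cc2cc(-c3ccc(F)cc3)[nH]c12` — 85.1%
compound 2 `COc1ccc(-c2cc(C(C)=O)c3[nH]c(-c4ccc(F)cc4)cc3c2)cc1` — 56.1%

Among the compounds with values here, in a functional assay on HeLa cells (Homo sapiens) for cytotoxicity, read by MTT assay, with a stated time of 2 days, tested at 1 uM (on this read-out lower numbers stand for a stronger effect and higher numbers for a weaker effect at the one concentration tested), compound 2 gives 56.1%, the lowest of the two numbers so far; compound 1 gives 85.1%, and the one step in hand, a number 29 percentage points lower from compound 1 to compound 2 (beyond the scatter), came with methoxy in place of hydrogen on an aromatic carbon. Compound 3 `COc1ccc(-c2cc(C(C)=O)c3[nH]c(-c4ccc(OC)cc4)cc3c2)cc1` is not yet measured. It differs from compound 2 by methoxy in place of fluoro on an aromatic carbon. Within the data shown here, no measured step exchanges fluoro for methoxy, so the step from compound 1 to compound 2 bears on it only loosely, as the sole sign that a methoxy group has moved this read-out. A second methoxy is therefore expected to lower the number at most modestly, with no change beyond the scatter also possible: the expected step is a number 10.1 percentage points lower from compound 2 to compound 3 (beyond the scatter). For compound 3 the estimate in this assay is 46%, ranging from 26% to 66%.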

Compound 3, a percentage reported as activity, at one concentration (the size of the read-out at that concentration, not a potency): 60.2%
For compound 3 the middle estimate is 14.2 percentage points below the measured one, within the range that was stated.
By their numbers in this assay, from the lowest: compounds 2 and 3 (each within the scatter of the next); then compound 1.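

In this assay the exchange of 4-fluorophenyl for 4-methoxyphenyl gives a number 4.1 percentage points higher from compound 2 to compound 3 (within the scatter) and so, at this place on an aromatic carbon para to a large group, fluoro and methoxy cannot be told apart on this read-out. The earlier step, a number 29 percentage points lower from compound 1 to compound 2 (beyond the scatter) on putting methoxy in place of hydrogen, lay beyond the scatter, whereas this exchange shows that adding a methoxy group at the second place does not bring a second such step. No measurement of any property is at hand to account for this result.

The compounds shown leave open whether hydrogen at this place would read differently from fluoro or methoxy, and whether an amine, a carboxylic acid or a longer chain there would shift the number. They also leave open how compound 2 and compound 3 would compare at any other concentration.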